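Homologation at the chain carbon bearing the phenyl cap

The compounds below may be only part of what the source reports. "The series", "measured", "known", "first", "only" and "open" are said of these compounds alone.

Measured so far in an assay on isolated protein for inhibition of histone deacetylase HD1B (Zea mays); on this read-out lower numbers stand for stronger inhibition and higher numbers for weaker inhibition:
- compound 1 `O=C(/C=C/c1ccccc1CSc1nc(O)cc(-c2ccccc2)n1)NO`: 780 nM
- compound 2 `CC(c1ccccc1)c1cc(O)nc(SCCCCCC(=O)NO)n1`: 92 nM

Compound 2 holds the lower of the two numbers in this assay. Its nearest neighbour, compound 1, is well apart from it, and since the two differ in more than one place nothing can be said about which part of the structure carries that gap; only the two values themselves are known.

Compound 3 `CCC(c1ccccc1)c1cc(O)nc(SCCCCCC(=O)NO)n1` has not yet been measured in this assay. It differs from compound 2 in one place: methyl in place of hydrogen on a saturated chain carbon, two bonds along the chain from two aromatic carbons. Cut one bond further out, the same difference reads methyl to ethyl. The hydroxamic acid, the six-carbon chain through sulfur and the shared core remain untouched.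

Among the compounds with values here, no step between measured compounds tests this kind of change, so there is no measured precedent to lean on. A single added carbon on a saturated chain carbon of the cap is a small change; the expected step from compound 2 to compound 3 in this assay is a 1.1-fold higher number from compound 2 to compound 3 (0.04 log units; within the scatter), most likely within the usual scatter. Compound 3 is therefore estimated at 100 nM, with a range from 40 nM to 250 nM.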

Compound 3, half-maximal inhibitory concentration: 31 nM
Estimate against measurement, compound 3: 3.2-fold (0.51 log units) above; measured number below the stated range.
By their numbers in this assay, from the lowest: compound 3; then compound 2; then compound 1.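

In this assay, within the data shown here, the change from methyl to ethyl at this saturated chain carbon gives a 3.0-fold lower number from compound 2 to compound 3 (0.47 log units; beyond the scatter), the first single-place comparison and the first sign that the number responds to the cap. A single added carbon at this position, with the hydroxamic acid, the six-carbon chain through sulfur and the shared core unchanged, is therefore enough to move the read-out beyond the usual scatter, and the movement is towards stronger inhibition. This is one step at one position, so it establishes a direction for methyl to ethyl only and no trend with chain length.

On these data alone, whether the gain continues with a longer chain such as propyl, holds with a branched group such as isopropyl, or survives a hydroxyl or an amine on the same carbon remains open, as does whether a comparable step would appear with the cap and core of compound 1. No measurement is available that bears on the reason for this step.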